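Adding trifluoromethyl to compound 1

The compounds below may be only part of what the source reports. "The series", "measured", "known", "first", "only" and "open" are said of these compounds alone.

- compound 1 `CC(=O)c1ccc2[nH]c(-c3ccccc3)nc2c1` gives > 100000 nM (a limit)
- compound 2 `CC(=O)c1ccc2[nH]c(-c3ccc(Cl)cc3)nc2c1` gives > 100000 nM (a limit)

In an ADME assay on MDBK cells (Bos taurus) for cytotoxicity, read by MTT assay, with a stated time of 96 h (on this read-out lower numbers stand for higher toxicity in this test and higher numbers for lower toxicity in this test), compound 1 stands at > 100000 nM as a limit, not a number. Compound 3 `CC(=O)c1ccc2[nH]c(-c3ccc(C(F)(F)F)cc3)nc2c1` has trifluoromethyl in place of hydrogen on an aromatic carbon. For the measured compounds named here, the one measured step that bears on this, chloro in place of hydrogen on an aromatic carbon, is a step that the two limits leave unreadable from compound 1 to compound 2 (the limit of > 100000 nM in this assay, at which 2 of the 2 values shown sit). No step beyond the scatter is therefore expected in this assay in either direction. The estimated step is a number no higher from compound 1 to compound 3 (the limit leaves the size open) in size. The estimated value for compound 3 is 100000 nM (expected range 45000 nM to 200000 nM).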

Compound 3, half-maximal cytotoxic concentration: > 100000 nM
Compound 3: only a limit was reported; the forecaster's own chance of this, stated with the estimate: 70%; the middle value sits exactly at the limit.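

Compound 1, compound 2 and compound 3 give no readable step in this assay, as each value is only a limit: the limit of > 100000 nM in this assay, at which 3 of the 3 values shown sit.

The compounds shown leave open whether chloro or trifluoromethyl in place of hydrogen changes this read-out at all.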